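The source may hold more compounds than are shown below. What is called first, only, known or untested is meant among the compounds shown, and "the series" means these compounds.

Of the compounds shown here, three sharing one core have been measured so far. Compound 1 `COc1ccc(-c2nc(/N=C(\N)[N+]3(C)CCCCC3)sc2-c2ccc(OC)cc2)cc1` carries, on an aromatic carbon of that core, a group of 10 heavy atoms (7 carbon, 3 nitrogen; one six-membered non-aromatic ring with 1 hetero atom). In a functional assay with Oryctolagus cuniculus as the target (a higher number here means a weaker inhibitor, a lower number a stronger inhibitor), compound 1 gives > 1000 nM, which is a limit of the assay rather than a number. Compound 2 `COc1ccc(-c2nc(CNC(=O)N3CCOCC3)sc2-c2ccc(OC)cc2)cc1` gives 660 nM in this assay. Compound 3 `COc1ccc(-c2nc(C(N)=O)sc2-c2ccc(OC)cc2)cc1` gives > 1000 nM, again only a limit. The steps of an at least 1.5-fold lower number from compound 1 to compound 2 (0.18 log units; that floor lies within the scatter) and an at least 1.5-fold higher number from compound 2 to compound 3 (0.18 log units; that floor lies within the scatter) can therefore be stated only as floors, and the step that the two limits leave unreadable from compound 1 to compound 3 cannot be read at all, because of the limit of > 1000 nM in this assay, at which 2 of the 3 values shown sit.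

Compound 4 `CCOC(=O)/C=C/c1nc(-c2ccc(OC)cc2)c(-c2ccc(OC)cc2)s1` is not yet measured. It differs from compound 1 as follows: a group of 7 heavy atoms (5 carbon, 2 oxygen; no ring) in place of a group of 10 heavy atoms (7 carbon, 3 nitrogen; one six-membered non-aromatic ring with 1 hetero atom), on an aromatic carbon. The two measured neighbours of compound 1 show that replacing the group of 10 heavy atoms carried by compound 1 gives, at best, the weak inhibition seen for compound 2 with 660 nM. For compound 3 only a limit is found. Compound 4 is therefore expected to sit near 1200 nM, most likely between 400 nM and 4000 nM. The expected step from compound 1 to compound 4 is a step that the limit leaves unreadable from compound 1 to compound 4, with a real chance that this assay again reports only a limit for compound 4.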

Compound 4, half-maximal inhibitory concentration: 20 nM
Compound 4: the middle estimate sits 60-fold (1.78 log units) above what was measured; the measured number lies below the stated range.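

Going by these compounds alone, the aromatic carbon next to the ring nitrogen and next to the ring sulfur can support much stronger inhibition in this assay than the earlier compounds showed: with 2-(ethoxycarbonyl)ethenyl in place of (((morpholin-4-yl)carbonyl)amino)methyl, the result is a 33-fold lower number from compound 2 to compound 4 (1.52 log units; beyond the scatter). The changes from the other two compounds are also large, an at least 50-fold lower number from compound 1 to compound 4 (1.69 log units; beyond the scatter) and an at least 50-fold lower number from compound 3 to compound 4 (1.69 log units; beyond the scatter), but both can be given only as floors: the limit of > 1000 nM in this assay, at which 2 of the 4 values shown sit. Several counted features change together between compound 1 and compound 4, including the loss of the ring and of the net charge of +1, and this single step does not say which of them matters.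

Going by these compounds, it also remains open which part of the 2-(ethoxycarbonyl)ethenyl group matters, a question that a carboxylic acid in place of the ethoxycarbonyl end, or the same chain with a single bond in place of its double bond, would address. Also open, on these data alone, is whether this strength depends on the two 4-methoxyphenyl groups, which all four compounds carry.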